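A few compounds are considered here, and "the series" means these few. Any claim that something is new, unique, unknown or untested is made for them only; others in the source may bear on it.

Measured in an ADME assay on RAW264.7 cells (Mus musculus) for cytotoxicity, read by MTT assay, with a stated time of 24 h, tested at 1.25 ug/mL; a lower number here means a stronger effect, a higher number a weaker effect of the compound at the concentration tested: compound 1, `COc1ccc(CCC(=O)c2cccc(O)c2)cc1`, gives 97.5%. Compound 2, `COc1ccc(C(=O)/C=C/c2ccc(OC)c(OC)c2)c(O)c1`, gives 99.7%. Compound 3, `COc1ccc(CCC(=O)c2cccc(O)c2)c(OC)c1`, gives 92.1%.

Among the measured compounds shown here, all three numbers lie within the scatter of one another, so no compound is set apart in this assay. Compound 3 differs from compound 1 by methoxy in place of hydrogen on an aromatic carbon, and that change made a number 5.4 percentage points lower from compound 1 to compound 3 (within the scatter). Compound 4, `COc1ccc(C(=O)/C=C/c2ccc(OC)c(OC)c2OC)c(O)c1`, is not yet measured; it differs from compound 2 by methoxy in place of hydrogen on an aromatic carbon. This is the same kind of change, not the same: in compound 4 the entering group is also ortho to a methoxy group. The difference between the cores of compound 1 and compound 2 is not broken down here. Because a number 5.4 percentage points lower from compound 1 to compound 3 (within the scatter) stayed within the scatter, compound 4 is expected to show a number 4.7 percentage points lower from compound 2 to compound 4 (within the scatter) in this assay. Compound 4 is thus estimated at 95%, between 85% and 103%.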

Compound 4, a percentage reported as activity, at one concentration (the size of the read-out at that concentration, not a potency): 98.5%
Compound 4: middle estimate off by 3.5 percentage points, on the low side; the measured number falls inside the stated range.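

In this assay, methoxy in place of hydrogen on an aromatic carbon gave a number 1.2 percentage points lower from compound 2 to compound 4 (within the scatter). Set beside the earlier step, the two cores do not part on this change: the same change on two cores in this assay, a number 5.4 percentage points lower (within the scatter) from compound 1 to compound 3 and a number 1.2 percentage points lower (within the scatter) from compound 2 to compound 4, 4.2 percentage points apart, within the scatter of two such steps. This shows that on these two cores the change left the read-out within the scatter at the one concentration tested, but it does not show that the change would carry to any other core, or that it would stay this small in a compound with a stronger effect in this assay.

The compounds shown leave open what an amine, a carboxylic acid or a longer alkoxy chain would do in place of that methoxy. They also leave open whether any such group would move the read-out beyond the scatter.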